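The source may report more compounds than this note shows. Statements on the series, on what has been measured and on what is new or still open speak of the compounds shown alone.

Compound 1 `c1ccc(CC2CCN(CCCCC3CCCc4ccccc43)CC2)cc1` is one of three compounds examined in an assay on isolated protein for binding affinity to Adrenergic receptor alpha-1 (Rattus norvegicus), read by radioligand binding; on this read-out lower numbers stand for stronger inhibition and higher numbers for weaker inhibition; compound 1 gives 30 nM, the second highest of the three numbers. Compound 2 `c1ccc2c(c1)CCN(CCCCC1CCCc3ccccc31)C2` gives 3.7 nM, a lower number, and compound 3 `COc1ccc2c(c1)C(CCCN1CCCCC1)CCC2` gives 63.2 nM, a higher number, so compound 1 lies between them. The compound not yet measured is compound 4 `c1ccc2c(c1)CCCC2CCCCN1CCCCC1`, which differs from compound 1 by hydrogen in place of benzyl on a saturated ring carbon. Within the data shown here, no measured pair shows this change directly, so the expected step from compound 1 to compound 4 in this assay, a 3.3-fold higher number from compound 1 to compound 4 (0.52 log units; beyond the scatter), is an estimate toward a higher number, modest but beyond the scatter. Compound 4 is thus expected to give about 100 nM, with a range from 30 nM to 400 nM.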

Compound 4, inhibition constant: 4.7 nM
Estimate against measurement, compound 4: 21-fold (1.33 log units) above, and the stated range ends above it.
By their numbers in this assay, from the lowest: compounds 2 and 4 (each within the scatter of the next); then compound 1; then compound 3.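

Among these compounds, replacing benzyl with hydrogen on the saturated ring carbon brings a 6.4-fold lower number from compound 1 to compound 4 (0.81 log units; beyond the scatter) in this assay, the first direct reading of this change. At this position, three ring bonds from the ring nitrogen, the benzyl is therefore not needed for a low number, and here it goes with a higher one. The compounds shown offer no measured explanation for this direction.

On these data alone, whether a smaller group, such as methyl or hydroxyl, would behave like hydrogen or like benzyl at this carbon remains open. So does whether phenyl would match benzyl here.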